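This account rests on a few compounds, and the source may have more. Where it says the series, first, only, none or still open, it means among the compounds named here.

Measured so far in an assay on cells for inhibition of Voltage-dependent T-type calcium channel subunit alpha-1H (Homo sapiens), read by FLIPR and calcium flux, with stated times of 600 s and 300 s; a lower number here means a stronger inhibitor, a higher number a weaker inhibitor:

- compound 1, `CN(Cc1ccc(OCCCN)cc1)c1nc2ccc(Oc3ccc(C#N)cc3)cc2s1`: 328000 nM
- compound 2, `CN(Cc1ccc(OCCCN)cc1)c1nc2ccc(Oc3ccc(C(F)(F)F)cc3)cc2s1`: 248000 nM
- compound 3, `CN(Cc1ccc(OCCCN)cc1)c1nc2ccc(Oc3ccc(F)cc3)cc2s1`: 492000 nM

Compound 3 gives the highest of the three numbers, but neither gap separates it from the others: the move a 1.5-fold higher number from compound 1 to compound 3 (0.18 log units; within the scatter) and the move a 2.0-fold higher number from compound 2 to compound 3 (0.30 log units; within the scatter) both stay inside the scatter, as does a 1.3-fold lower number from compound 1 to compound 2 (0.12 log units; within the scatter). Across these three the substituent on the outer aromatic ring has not produced a resolvable difference in this assay.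

Compound 4, `CN(Cc1ccc(OCCCN)cc1)c1nc2ccc(Oc3cccc(C(F)(F)F)c3)cc2s1`, is not yet measured. It differs from compound 3 by 3-(trifluoromethyl)phenyl in place of 4-fluorophenyl on an oxygen on an aromatic ring. For the measured compounds named here, the only measured step that touches a fluoro-to-trifluoromethyl exchange is the reverse of a 2.0-fold higher number from compound 2 to compound 3 (0.30 log units; within the scatter), which was within the scatter; no measured pair covers a change of ring position for the trifluoromethyl group, so that part of the change is unsupported by data. The expectation is therefore a step of a 1.6-fold lower number from compound 3 to compound 4 (0.21 log units; within the scatter), most likely not beyond the scatter. Compound 4 is expected to give about 300000 nM, with a range from 110000 nM to 850000 nM.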

Compound 4, half-maximal inhibitory concentration: 239000 nM
Beside the measured number, compound 4's estimate is 1.3-fold (0.10 log units) above it, within the range that was stated.
By their numbers in this assay, from the lowest: compounds 4, 2, 1 and 3 (each within the scatter of the next, the first and the last beyond it).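

In this assay, the group on the oxygen now gives a step beyond the scatter, a 2.1-fold lower number from compound 3 to compound 4 (0.31 log units; beyond the scatter), though only a modest one. Moving the trifluoromethyl group on the ring resolves nothing, a 1.0-fold lower number from compound 2 to compound 4 (0.02 log units; within the scatter), and 3-(trifluoromethyl)phenyl is likewise not separated from 4-cyanophenyl, a 1.4-fold lower number from compound 1 to compound 4 (0.14 log units; within the scatter), so the single resolved step sets 3-(trifluoromethyl)phenyl apart only from 4-fluorophenyl. No evidence on the origin of this step is at hand.

On these data alone, it remains open whether an outer ring bearing an amine or a carboxylic acid, or a pyridine or cyclohexyl ring in place of the phenyl, would shift the number further than these substituted phenyl groups do. As far as these compounds go, the response to changes elsewhere on the shared core also remains open.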